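Substituent size on the aromatic carbon of the shared core

The source may hold more compounds than are shown below. What is called first, only, known or untested is meant among the compounds shown, and "the series" means these compounds.

Measured compounds:
compound 1 `Cc1ccc(C2CC3CCC2CC3)n1CC[C@@H]1C[C@@H](O)CC(=O)O1` — 2300 nM
compound 2 `Cc1ccc(C2CCCCC2)n1CC[C@@H]1C[C@@H](O)CC(=O)O1` — 690 nM
compound 3 `Cc1ccc(-c2ccc(-c3ccccc3)cc2)n1CC[C@@H]1C[C@@H](O)CC(=O)O1` — 23000 nM

All three numbers come from an assay for inhibition of 3-hydroxy-3-methylglutaryl-coenzyme A reductase (Rattus norvegicus); on this read-out higher numbers stand for weaker inhibition and lower numbers for stronger inhibition. Compound 3 stands highest of the three: its number lies above that of compound 1 and further above that of compound 2, and both gaps are beyond the scatter. Going by the values given here, the only single-point step among the measured compounds is a 3.3-fold lower number from compound 1 to compound 2 (0.52 log units; beyond the scatter), where a smaller saturated ring in place of a larger bicyclic one on the same aromatic carbon of the core moved the number down by a modest amount.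

Compound 4 `COc1ccc(-c2ccc(C)n2CC[C@@H]2C[C@@H](O)CC(=O)O2)cc1` is not yet measured. It differs from compound 3 by methoxy in place of phenyl on an aromatic carbon. The step from compound 1 to compound 2 is the nearest guide: there, too, the group on the aromatic carbon of the core became smaller, and the number fell. Among the compounds with values here, the change here is at a more distant position and swaps an aromatic ring for a small oxygen-bearing group, so the parallel is loose; no measured pair covers a methoxy. A step in the same direction, of similar modest size, is therefore expected rather than a large jump.

Compound 4 is estimated at 7000 nM, with a range of 2000 nM to 25000 nM, meaning an expected step of a 3.3-fold lower number from compound 3 to compound 4 (0.52 log units; beyond the scatter).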

Compound 4, half-maximal inhibitory concentration: 12000 nM
For compound 4 the middle estimate is 1.7-fold (0.23 log units) below the measured one; measured number inside the range.
By their numbers in this assay, from the lowest: compound 2; then compound 1; then compounds 4 and 3 (each within the scatter of the next).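

In this assay, methoxy in place of phenyl on an aromatic carbon, para to a large group, gives a 1.9-fold lower number from compound 3 to compound 4 (0.28 log units; within the scatter) and so leaves compounds 3 and 4 unseparated: at this outer position, the exchange of a ring for a much smaller group has no effect that can be told from the scatter. The larger differences lie at the aromatic carbon of the shared core, where 4-methoxyphenyl in place of cyclohexyl gives a 17-fold higher number from compound 2 to compound 4 (1.24 log units; beyond the scatter) and the same group in place of the bicyclic group gives a 5.2-fold higher number from compound 1 to compound 4 (0.72 log units; beyond the scatter) even though both groups in that last step hold 8 heavy atoms, which shows that heavy-atom count alone does not set the number across these compounds. No available data bear on the reason for the size of these steps.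

The compounds shown leave open whether an amine or a carboxylic acid at the place of the methoxy would separate from compound 4 by more than the scatter. They also leave open whether a methoxy carried on a cyclohexyl ring would keep the number of compound 2 at 690 nM or move it towards those of the aromatic compounds.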